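The source may report more compounds than this note shows. Statements on the series, on what has been measured and on what is new or still open speak of the compounds shown alone.

Measured so far in a functional assay on MCF7 cells (Homo sapiens) for cytotoxicity, read by MTT assay; a higher number here means a weaker inhibitor, a lower number a stronger inhibitor:
- compound 1 `COc1ccc(/C=C2\CCC/C(=C\c3cccc([N+](=O)[O-])c3)C2=O)cc1`: 5.71 ug/mL
- compound 2 `COc1cccc(/C=C2\CCC/C(=C\c3cccc([N+](=O)[O-])c3)C2=O)c1`: 4.17 ug/mL

Within the data shown here, compound 2 has the lowest of the two numbers, but its only neighbour, compound 1, sits within the scatter: the step of a 1.4-fold lower number from compound 1 to compound 2 (0.14 log units; within the scatter) shows that moving the methoxy group on one aryl ring from one position to another made no difference that can be trusted.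

Compound 3 `O=C1/C(=C/c2ccc([N+](=O)[O-])cc2)CCC/C1=C\c1cccc([N+](=O)[O-])c1` has not yet been measured. Compared with compound 2 the change is 4-nitrophenyl in place of 3-methoxyphenyl on a double-bonded chain carbon bound to a double-bonded ring carbon, so that both chain carbons now carry a nitrophenyl ring. Among the measured compounds shown here, no measured step touches this kind of exchange; the single step from compound 1 to compound 2 concerns only where a methoxy group sits and says nothing about swapping a methoxy group for a nitro group. With no guide, the expectation for compound 3 is a step of a 1.1-fold higher number from compound 2 to compound 3 (0.03 log units; within the scatter) that stays within the scatter. Compound 3 is therefore estimated at 4.5 ug/mL, with a range from 1.8 ug/mL to 11 ug/mL.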

Compound 3, half-maximal inhibitory concentration: 8.4 ug/mL
Compound 3: middle estimate off by 1.9-fold (0.27 log units), on the low side; the range from low to high includes it.
By their numbers in this assay, from the lowest: compounds 2, 1 and 3 (each within the scatter of the next).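

In this assay the exchange of 3-methoxyphenyl for 4-nitrophenyl on a double-bonded chain carbon bound to a double-bonded ring carbon gives a 2.0-fold higher number from compound 2 to compound 3 (0.30 log units; within the scatter) and stays at the edge of the scatter. Nitro in place of methoxy on an aromatic carbon gives a 1.5-fold higher number from compound 1 to compound 3 (0.17 log units; within the scatter) and also stays within it, so this position has now taken a different group, not just a moved methoxy group, without a change that can be trusted. Nothing measured here says why the numbers stay so close.

As far as these compounds go, whether a different group at this position, such as an amine or a carboxylic acid, would shift the number beyond the scatter remains open. From the compounds shown here alone, all three compounds also keep the other nitrophenyl ring, so what an exchange of that ring would do is unknown too.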